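The source may report more compounds than this note shows. Statements on the series, on what has been measured and on what is new or still open speak of the compounds shown alone.

Of the compounds shown here, three built on a shared core have been measured in a physicochemical assay for lipophilicity, read by HPLC, at pH 7.4; on this read-out higher numbers stand for higher lipophilicity and lower numbers for lower lipophilicity. Compound 1, `C[C@@H](Oc1cc2onc(CCC(=O)O)c2cc1Cl)c1ccc(F)cn1`, gives 2.47. Compound 2, `C[C@@H](Oc1cc2sc(=O)n(CCC(=O)O)c2cc1Cl)c1ccccn1`, gives 1.81. Compound 3, `C[C@@H](Oc1cc2oc(=O)n(CCC(=O)O)c2cc1Cl)c1ccc(F)cn1`, gives 1.98, which stands second highest among the three numbers; its nearest neighbour is compound 2, separated from it by a gap that lies within the scatter of this assay, while its furthest is compound 1, which lies higher by a gap beyond the scatter.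

Compound 4, `C[C@@H](Oc1cc2oc(=O)n(CCC(=O)O)c2cc1Cl)c1ncco1`, has not yet been measured in this assay. It differs from compound 3 in a single place: 1,3-oxazol-2-yl in place of 5-fluoropyridin-2-yl on a saturated chain carbon bound to an oxygen on an aromatic ring and a saturated chain carbon. Among the measured compounds shown here, no pair of measured compounds differs in only one place, so there is no measured step on which the expectation can rest directly; it rests on the structural change alone. A six-membered aromatic ring with one hetero atom and one hydrogen-bond acceptor leaves, and a five-membered aromatic ring with two hetero atoms and two hydrogen-bond acceptors enters, on the saturated chain carbon bound to an oxygen on an aromatic ring. On that basis a downward step from compound 3 to compound 4, beyond the scatter, is expected: a number 0.68 log units lower from compound 3 to compound 4 (beyond the scatter). For compound 4 the estimate in this assay is 1.3, with a range from 0.9 to 1.7.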

Compound 4, distribution coefficient: 1.11
Estimate against measurement, compound 4: 0.19 log units above, within the range that was stated.
By their numbers in this assay, from the lowest: compound 4; then compounds 2 and 3 (each within the scatter of the next); then compound 1.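

Among the compounds shown here, the swap of 5-fluoropyridin-2-yl for 1,3-oxazol-2-yl, on a saturated chain carbon bound to an oxygen on an aromatic ring and a saturated chain carbon, provides the first single-place step in this set: this assay gives a number 0.87 log units lower from compound 3 to compound 4 (beyond the scatter). For the compounds shown here, it shows that this read-out responds to the group at this place when the rest of the structure is held constant, which the earlier compounds could not show, as no two of them differed in only one place. Ring size, heavy-atom count, hetero atoms and hydrogen-bond acceptors all change together in this one step, and nothing presented here accounts for the size of the fall or assigns it to any one of these features.

Going by these compounds, it remains open how a phenyl ring or a 1,3-thiazol-2-yl group at this place would read, and either could help to separate ring size from the identity of the hetero atoms. On these data alone, it also remains open whether the same swap would give a step of similar size on the core of compound 1 or of compound 2.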